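Side-group swap from compound 3 to compound 4

A few compounds are considered here, and "the series" means these few. Any claim that something is new, unique, unknown or untested is made for them only; others in the source may bear on it.

Measured so far in a physicochemical assay for solubility, at pH 7.4; a lower number here means a less soluble compound, a higher number a more soluble compound:
- compound 1 `CNC1(C)CN(c2cc3c(cc2F)c(=O)c(C(=O)O)cn3C2CC2)C1`: 0.7 ug/mL
- compound 2 `C[C@H]1[C@H](N)CN1c1cc2c(cc1F)c(=O)c(C(=O)O)cn2C1CC1`: 9.9 ug/mL
- compound 3 `CNC1(C)CN(c2c(F)cc3c(=O)c(C(=O)O)cn(C4CC4)c3c2F)C1`: 0.5 ug/mL

Compound 3 stands at 0.5 ug/mL, and compound 1 at 0.7 ug/mL lies within the scatter of it. Compound 2 at 9.9 ug/mL is well higher than both.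

The next compound is compound 4 `CN(C)C1CN(c2c(F)cc3c(=O)c(C(=O)O)cn(C4CC4)c3c2F)C1`, with the same atoms as compound 3 joined differently: 3-(dimethylamino)azetidin-1-yl in place of 3-methyl-3-(methylamino)azetidin-1-yl on an aromatic carbon. The change is 3-(dimethylamino)azetidin-1-yl in place of 3-methyl-3-(methylamino)azetidin-1-yl, ortho to two fluoro groups.

Going by the values given here, no measured step makes this exact swap. The closest guide is the large side-group step a 14-fold higher number from compound 1 to compound 2 (1.15 log units; beyond the scatter), which involves a different incoming group. The fluoro step a 1.4-fold lower number from compound 1 to compound 3 (0.15 log units; within the scatter) stays within the scatter and says little about the swap. A modest rise in this assay is therefore expected, well short of that large step, and a result within the scatter remains possible.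

The expected change is a 3.0-fold higher number from compound 3 to compound 4 (0.48 log units; beyond the scatter). For compound 4 the estimated value is 1.5 ug/mL, with an expected range of 0.4 ug/mL to 6 ug/mL.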

Compound 4, solubility: 58 ug/mL
For compound 4 the middle estimate is 39-fold (1.59 log units) below the measured one; the whole stated range lies below it.
By their numbers in this assay, from the lowest: compounds 3 and 1 (each within the scatter of the next); then compound 2; then compound 4.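

At this position, on an aromatic carbon ortho to two fluoro groups, joining the same side-group atoms differently gives a 120-fold higher number from compound 3 to compound 4 (2.06 log units; beyond the scatter) in this assay. The earlier side-group step, a 14-fold higher number from compound 1 to compound 2 (1.15 log units; beyond the scatter), changed the heavy-atom count, whereas here the count is unchanged and the groups differ in hydrogen-bond donors, with 1 leaving and 0 entering. Nothing available gives a measured reason for the size of this step.

On these data alone, the swap moves the methyl off the ring carbon and onto the nitrogen in a single change, so the part played by each move stays open; a 3-(methylamino)azetidin-1-yl group on the same core would separate them. As far as these compounds go, whether 3-(dimethylamino)azetidin-1-yl gives a similar step on the core of compound 1, with hydrogen in place of the second fluoro, also remains open.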